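The source may hold more compounds than are shown below. What is called first, only, known or untested is meant among the compounds shown, and "the series" means these compounds.

Series notes. The shared core is constant; only the substituent on the oxygen on the aromatic ring varies. Compound 1 `CC(C)Oc1cccc2ccc(N)nc12` carries isopropyl, and in an assay on cells with melanin-concentrating hormone receptor 1 (Homo sapiens) as the target, read by radioligand binding (a lower number here means a stronger inhibitor, a higher number a weaker inhibitor), compound 1 gives 437 nM. Compound 2 `CCCC(C)Oc1cccc2ccc(N)nc12` carries 1-methylbutyl; in this assay compound 2 gives 105 nM, the step of a 4.2-fold lower number from compound 1 to compound 2 (0.62 log units; beyond the scatter) being ethyl in place of hydrogen on a saturated chain carbon, two bonds along the chain from an oxygen on an aromatic ring. Compound 3 `CCOCCOc1cccc2ccc(N)nc12` carries 2-ethoxyethyl. In this assay compound 3 reaches only > 2000 nM, which is a limit of the assay and not a number. The value of compound 3 sits at the limit of > 2000 nM in this assay, at which 1 of the 3 values shown sits. With an at least 4.5-fold higher number from compound 1 to compound 3 (0.66 log units; beyond the scatter) and an at least 19-fold higher number from compound 2 to compound 3 (1.27 log units; beyond the scatter) both beyond the scatter, compound 3 stands weakest of the three measured.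

Compound 4 `CC(C)C(C)Oc1cccc2ccc(N)nc12` is not yet measured. Its change from compound 3 is 1,2-dimethylpropyl in place of 2-ethoxyethyl on an oxygen on an aromatic ring. Read in reverse, the steps of an at least 4.5-fold higher number from compound 1 to compound 3 (0.66 log units; beyond the scatter) and an at least 19-fold higher number from compound 2 to compound 3 (1.27 log units; beyond the scatter) bear on it, so a modest to large drop in number is expected, back toward compound 1 and compound 2. As 1,2-dimethylpropyl is a branched alkyl like isopropyl and 1-methylbutyl, compound 4 is expected to land between compound 1 and compound 2. The expected step is an at least 11-fold lower number from compound 3 to compound 4 (1.04 log units; beyond the scatter). Compound 4 is estimated at 180 nM in this assay, with a range from 60 nM to 550 nM.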

Compound 4, half-maximal inhibitory concentration: 199 nM
Compound 4: the middle estimate sits 1.1-fold (0.04 log units) below what was measured; measured number inside the range.
By their numbers in this assay, from the lowest: compounds 2 and 4 (each within the scatter of the next); then compound 1. At a limit, above all of these: compound 3.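

In this assay, 2-ethoxyethyl and 1,2-dimethylpropyl each have 5 heavy atoms and no ring, yet exchanging them gives an at least 10-fold lower number from compound 3 to compound 4 (1.00 log units; beyond the scatter), so heavy-atom count alone does not set the result on an oxygen on an aromatic ring; the entering group has 0 hydrogen-bond acceptors and the leaving group has 1, and it also differs in branching. Compound 3 remains a limit of the assay and not a number: the limit of > 2000 nM in this assay, at which 1 of the 4 values shown sits. Among the alkyl groups, the change shows a 2.2-fold lower number from compound 1 to compound 4 (0.34 log units; beyond the scatter), while a 1.9-fold higher number from compound 2 to compound 4 (0.28 log units; within the scatter) stays within the scatter, so isopropyl and propyl on a saturated chain carbon bound to an oxygen on an aromatic ring and a saturated chain carbon are not told apart here, and both 1-methylbutyl and 1,2-dimethylpropyl give lower numbers than isopropyl on the oxygen.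

The ether oxygen and the lack of branching in 2-ethoxyethyl remain tied together, and an unbranched pentyl chain in this assay would be needed to separate them. On these data alone, how a cyclopentyl group or a chain ending in an amine would read at this oxygen also stays open.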